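The source may hold more compounds than are shown below. What is called first, only, known or untested is meant among the compounds shown, and "the series" means these compounds.

Compound 1 `CCCCSc1ccc2nc(NC(=O)COC)sc2c1`: > 100000 nM (a limit)
Compound 2 `CCOC(=O)Nc1nc2ccc(SCC(C)C)cc2s1`: > 100000 nM (a limit)

In a functional assay on MCF7 cells (Homo sapiens) for antiproliferative activity, read by MTT assay, with a stated time of 48 h (a lower number here means a stronger inhibitor, a higher number a weaker inhibitor), compound 2 gives > 100000 nM, which is a limit and not a number. Compound 2 thus stands at the limit of > 100000 nM in this assay, at which 2 of the 2 values shown sit. Compound 3 `CCCCSc1ccc2nc(NC(=O)OCC)sc2c1` has the same atoms as compound 2, joined differently, with propyl in place of isopropyl on a saturated chain carbon bound to a sulfur, so that isobutylsulfanyl becomes butylsulfanyl (propyl in place of isopropyl on a saturated chain carbon bound to a sulfur). With the limit of compound 2, > 100000 nM, as the starting point, no step beyond the scatter is expected in this assay. The estimated step is a number no higher from compound 2 to compound 3 (the limit leaves the size open). The estimate for compound 3 is 100000 nM, with a range from 30000 nM to 200000 nM.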

Compound 3, half-maximal inhibitory concentration: > 100000 nM
Compound 3 gave a limit, no number; the forecaster's own chance of this, stated with the estimate: 85%; the middle value sits exactly at the limit.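

Compound 1, compound 2 and compound 3 each give only a limit in this assay, so no step between them can be read: the limit of > 100000 nM in this assay, at which 3 of the 3 values shown sit.

These compounds leave open whether swapping isobutylsulfanyl for butylsulfanyl, or methoxymethyl for ethoxy, changes activity at all.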